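Series notes: methyl to hydrogen on an aromatic oxygen

The source may report more compounds than this note shows. Statements on the series, on what has been measured and on what is new or still open speak of the compounds shown alone.

Compound 1 `COc1cc(OC)c(C(=O)/C=C/c2ccccc2SC)c(OC)c1` gives 8800 nM in a functional assay on Caco-2 cells (Homo sapiens) for cytotoxicity, with a stated time of 48 h; on this read-out higher numbers stand for weaker inhibition and lower numbers for stronger inhibition. Compound 2 `COc1cccc(/C=C/C(=O)c2c(OC)cc(OC)cc2OC)c1` gives 3900 nM, the lowest of the three numbers, and compound 3 `COc1cc(O)c(C(=O)/C=C/c2ccccc2SC)c(OC)c1` gives 9600 nM. The two cores are told apart by 3-methoxyphenyl in place of 2-(methylsulfanyl)phenyl on a double-bonded chain carbon bound to a double-bonded chain carbon; this change gives a 2.3-fold lower number from compound 1 to compound 2 (0.35 log units; beyond the scatter). The other change measured so far is hydrogen in place of methyl on an oxygen on an aromatic ring, which gives a 1.1-fold higher number from compound 1 to compound 3 (0.04 log units; within the scatter), a step that cannot be separated from the scatter.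

Compound 4 `COc1cccc(/C=C/C(=O)c2c(O)cc(OC)cc2OC)c1` is not yet measured. Going by the values given here, it carries the change hydrogen in place of methyl on an oxygen on an aromatic ring relative to compound 2, and this is the same change as the one from compound 1 to compound 3: the place is the same, on an oxygen on an aromatic ring whose other neighbours are aromatic carbon, and the change occurs twice among the four compounds. Among the compounds with values here, the only evidence on this change is a 1.1-fold higher number from compound 1 to compound 3 (0.04 log units; within the scatter), which stays within the scatter, so the step from compound 2 to compound 4 is expected to be about as small, a 1.1-fold higher number from compound 2 to compound 4 (0.03 log units; within the scatter). Whether the core of compound 2 answers this change differently from the core of compound 1 is not known. Compound 4 is therefore estimated at 4200 nM in this assay, with a range from 2000 nM to 9000 nM.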

Compound 4, half-maximal inhibitory concentration: 11200 nM
For compound 4 the middle estimate is 2.7-fold (0.43 log units) below the measured one; the measured number lies above the stated range.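

Methoxy to hydroxy, on an oxygen on an aromatic ring, gives a 2.9-fold higher number from compound 2 to compound 4 (0.46 log units; beyond the scatter) in this assay. Set beside the earlier step, the two readings of this change cannot be told apart: the same change on two cores in this assay, a 1.1-fold higher number (0.04 log units; within the scatter) from compound 1 to compound 3 and a 2.9-fold higher number (0.46 log units; beyond the scatter) from compound 2 to compound 4, 2.6-fold (0.42 log units) apart, within the scatter of two such steps. The series therefore gives no firm sign that the core alters the response to this change, but two pairs do not show that the change carries over with the same size, as one step lies within the scatter and the other beyond it.

The compounds shown leave open how the read-out responds when the methyl on this oxygen gives way to something other than hydrogen, such as an ethyl group, a longer chain ending in an amine, or a chain ending in a carboxylic acid. They also leave open whether a third core would answer methoxy to hydroxy as the core of compound 1 does, as the core of compound 2 does, or in another way.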